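The source may report more compounds than this note shows. Statements on the series, on what has been measured and on what is new or still open speak of the compounds shown alone.

Working notes on the series. Compound 1 `COc1cc(-c2nnc3n2NC(c2ccco2)C(C(=O)c2ccccc2C)S3)cc(OC)c1OC` is the reference point: in a functional assay on MCF7 cells (Homo sapiens) for cytotoxicity, read by MTT assay, with a stated time of 48 h (on this read-out higher numbers stand for weaker inhibition and lower numbers for stronger inhibition), compound 1 gives 69900 nM. Compound 2 `COc1cc(-c2nnc3n2NC(c2ccco2)C(C(=O)c2ccc(F)cc2)S3)cc(OC)c1OC` differs only in the group on the carbonyl carbon. In this assay compound 2 returns no number but a limit of the assay, > 100000 nM. Compound 3 `COc1cc(-c2nnc3n2NC(c2ccco2)C(C(=O)c2cccc4ccccc24)S3)cc(OC)c1OC` likewise returns only a limit in this assay, > 100000 nM. Accordingly the steps read as an at least 1.4-fold higher number from compound 1 to compound 2 (0.15 log units; that floor lies within the scatter) and an at least 1.4-fold higher number from compound 1 to compound 3 (0.15 log units; that floor lies within the scatter), while a step that the two limits leave unreadable from compound 2 to compound 3. The whole set sits at the weak end of the read-out, with the limit of > 100000 nM in this assay, at which 2 of the 3 values shown sit, marking where most of it lies.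

For the measured compounds named here, compound 4 `COc1cccc(C(=O)C2Sc3nnc(-c4cc(OC)c(OC)c(OC)c4)n3NC2c2ccco2)c1` is the next variation at the same place. 3-methoxyphenyl in place of 4-fluorophenyl on a carbonyl carbon Since compound 2 stands only at a limit, no measured step can be anchored to it; the steps that bear on this change, an at least 1.4-fold higher number from compound 1 to compound 2 (0.15 log units; that floor lies within the scatter) and an at least 1.4-fold higher number from compound 1 to compound 3 (0.15 log units; that floor lies within the scatter), show that exchanging the group on the carbonyl carbon has so far left the number at or beyond the limit. The estimate therefore implies a step of a number no higher from compound 2 to compound 4 (the limit leaves the size open) that is expected to remain within the scatter, with a substantial chance that only a limit is reported again. Compound 4 is estimated at 100000 nM in this assay, within a range from 40000 nM to 300000 nM.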

Compound 4, half-maximal inhibitory concentration: > 100000 nM
Compound 4 ended at the assay's limit; the forecaster's own chance of this, stated with the estimate: 55%; the middle value sits exactly at the limit.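

Compound 4 also returns only a limit in this assay, so a hydrogen-bond acceptor on the group at the carbonyl carbon, present in 3-methoxyphenyl and absent from 4-fluorophenyl, gives no number here; the steps from compound 2 to compound 4 and from compound 3 to compound 4 join two limits and cannot be read. For the compounds shown here, the only readable step is an at least 1.4-fold higher number from compound 1 to compound 4 (0.15 log units; that floor lies within the scatter). Compound 1 therefore remains the only compound with a measured number, and a third group at this place has joined the same limit: the limit of > 100000 nM in this assay, at which 3 of the 4 values shown sit.

The compounds shown carry only aromatic carbon rings on the carbonyl carbon, so it remains open how a saturated amine or a carboxylic acid-bearing chain at this place would read out in this assay. The rest of the shared core is identical in all of them, which leaves open whether a change elsewhere would bring the series clear of the limit.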